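Thiomorpholine Amide Replaces a Thiophenylmethyl Amide

The source may hold more compounds than are shown below. What is called first, only, known or untested is meant among the compounds shown, and "the series" means these compounds.

Measured so far:
compound 1 `O=C(NCc1ccco1)c1ccc(C#Cc2ccccc2)nc1`: 180 nM
compound 2 `O=C(NCc1ccsc1)c1ccc(C#Cc2ccccc2)nc1`: 140 nM

In a functional assay on BHK cells for positive allosteric modulation of metabotropic glutamate receptor 5 (Homo sapiens), read by FLIPR and calcium flux (on this read-out higher numbers stand for an effect only at larger amounts of compound and lower numbers for an effect already at smaller amounts), compound 2 gives 140 nM, the lowest of the two numbers. Its nearest neighbour is compound 1 with 180 nM; the step of a 1.3-fold lower number from compound 1 to compound 2 (0.11 log units; within the scatter) lies within the scatter, so the two stand level. Compound 3 `O=C(c1ccc(C#Cc2ccccc2)nc1)N1CCSCC1` alters the amide side: thiomorpholin-4-yl in place of ((thiophen-3-yl)methyl)amino on a carbonyl carbon. Among the compounds with values here, no measured step bears directly on this exchange. Within the data shown here, the only step in hand, from compound 1 to compound 2, swapped one five-membered aromatic ring for another and kept the amide hydrogen in place. Compound 3 gives up that hydrogen and the aromatic ring together, a larger alteration, so a weakening beyond the scatter is expected, though its size is uncertain. Compound 3 is therefore estimated at 600 nM, in the range 150 nM to 3000 nM. The expected step is a 4.3-fold higher number from compound 2 to compound 3 (0.63 log units; beyond the scatter).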

Compound 3, half-maximal effective concentration: 46 nM
Compound 3: middle estimate off by 13-fold (1.12 log units), on the high side; measured number outside the range, below it.
By their numbers in this assay, from the lowest: compound 3; then compounds 2 and 1 (each within the scatter of the next).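

In this assay, within the data shown here, the carbonyl carbon tolerates a larger change than the earlier compounds showed: thiomorpholin-4-yl, a six-membered non-aromatic ring with no hydrogen-bond donor, gives a lower number than either amide carrying a five-membered aromatic ring (a 3.0-fold lower number from compound 2 to compound 3 (0.48 log units; beyond the scatter); a 3.9-fold lower number from compound 1 to compound 3 (0.59 log units; beyond the scatter)). Both steps lie beyond the scatter, whereas the exchange of one five-membered aromatic ring for the other stayed within it, so among these compounds neither the amide hydrogen nor an aromatic ring is required at this place. Nothing at hand accounts for the lower number.

Still open, as far as these compounds go, is whether the ring sulfur matters, which morpholin-4-yl or piperidin-1-yl on the same carbonyl carbon would test. Compound 3 also changes the amide hydrogen and the aromatic ring together, leaving open which of the two changes accounts for the step.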